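Shortening a Side Chain in a Cell-Growth Series

This account rests on a few compounds, and the source may have more. Where it says the series, first, only, none or still open, it means among the compounds named here.

Compound 1 is `CCOC(=O)CCO/N=C(/c1ccc(OC)c(OC)c1OC)c1cccc2ccccc12`; in a functional assay on MCF7 cells (Homo sapiens) for inhibition, read by sulforhodamine B assay, with a stated time of 48 h (a lower number here means a stronger inhibitor, a higher number a weaker inhibitor), compound 1 gives only a limit, > 20000 nM. Compound 3 is `COc1ccc(/C(=N/O)c2cccc3ccccc23)c(OC)c1OC`; in this assay compound 3 also gives only a limit, > 20000 nM. Compound 2 is `COc1ccc(C(O)(C/C=C\c2ccccc2)c2cccc3ccccc23)c(OC)c1OC`; in this assay compound 2 gives 10200 nM.

Within the data shown here, compound 2 thus stands as the only real number; compounds 1 and 3 both sit at the limit of > 20000 nM in this assay, at which 2 of the 3 values shown sit, so the step that the two limits leave unreadable from compound 1 to compound 3 cannot be read.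

Compound 4 is `C=CCC(O)(c1ccc(OC)c(OC)c1OC)c1cccc2ccccc12`. Its difference from compound 2: vinyl in place of 2-phenylethenyl on a saturated chain carbon, two bonds along the chain from two aromatic carbons and an oxygen on a saturated carbon. Among the measured compounds shown here, no measured step covers this change. Compound 4 is expected at 15000 nM, within 6000 nM to 40000 nM. The expected step of a 1.5-fold higher number from compound 2 to compound 4 (0.17 log units; within the scatter) is estimated to stay within scatter.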

Compound 4, half-maximal inhibitory concentration: > 20000 nM
Compound 4: no number, only a limit (the forecaster's own chance of this, stated with the estimate: 40%); middle value at least 1.3-fold (0.12 log units) away from the limit.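

In this assay, putting vinyl in place of 2-phenylethenyl on this chain gives an at least 1.9-fold higher number from compound 2 to compound 4 (0.29 log units; that floor lies within the scatter). Among these compounds, this is the first step that can be read at all, but it gives only a floor, and the true size stays unknown. Among the compounds shown, only compound 2 gives a real number: the limit of > 20000 nM in this assay, at which 3 of the 4 values shown sit.

Going by these compounds, it remains open how far compound 4 really lies from compound 2. On these data alone, it is also open whether a 2-phenylethyl group, or an amine at the end of the chain, would give a readable number.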